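Removing the Cyclopropyl from a Core That Shows No Activity

The compounds below may be only part of what the source reports. "The series", "measured", "known", "first", "only" and "open" are said of these compounds alone.

Compound 1 `O=C1COc2ccc(-c3cccc(NS(=O)(=O)c4ccc(F)cc4)c3)cc2N1C1CC1` is built on a shared core, and in a functional assay on A-375 cells (Homo sapiens) for antiproliferative activity, read by MTT assay, with a stated time of 72 h (on this read-out higher numbers stand for weaker inhibition and lower numbers for stronger inhibition), compound 1 gives > 40000 nM, which is a limit of the assay rather than a number. Two related compounds carry a different group at the same position of that core. Compound 2 `O=C1COc2ccc(-c3cnc4ccccc4c3)cc2N1c1ccccc1` also returns only a limit, giving > 40000 nM in this assay. Compound 3 `O=C1COc2ccc(-c3cnc4ccccc4c3)cc2N1c1ccc(Cl)cc1` likewise stops at the limit, with > 40000 nM in this assay. The step that the two limits leave unreadable from compound 2 to compound 3, chloro in place of hydrogen on an aromatic carbon, cannot be read because of the limit of > 40000 nM in this assay, at which 3 of the 3 values shown sit. Compound 1 thus stands at the same limit as compounds 2 and 3, and no measured number separates any of them.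

Compound 4 `O=C1COc2ccc(-c3cccc(NS(=O)(=O)c4ccc(F)cc4)c3)cc2N1` differs from compound 1 by hydrogen in place of cyclopropyl on an amide-type nitrogen in a ring. Going by the values given here, no measured step covers this change, and the only step on record, from compound 2 to compound 3, lies between two limits and says nothing about size. With every measured value sitting at the limit, the expected step that the limit leaves unreadable from compound 1 to compound 4 is estimated as none beyond the scatter. Compound 4 is therefore expected to give about 50000 nM in this assay, within 20000 nM to 120000 nM, and will most likely return only a limit as well.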

Compound 4, half-maximal inhibitory concentration: 20100 nM
The estimate for compound 4 lay 2.5-fold (0.40 log units) above the measured number; the measured number falls inside the stated range.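

Compound 4 is the only one of the compounds shown to return a number rather than a limit in this assay, so this position on the amide-type nitrogen in a ring is the first place where a change moves the read-out off the limit. Hydrogen in place of cyclopropyl gives an at least 1.9-fold lower number from compound 1 to compound 4 (0.29 log units; that floor lies within the scatter), so the printed floor of this step does not by itself separate the two compounds beyond the scatter, although the real step may be larger. Neither its full size nor any other step among these compounds can be read because the values concerned stand at a limit: the limit of > 40000 nM in this assay, at which 3 of the 4 values shown sit.

The compounds shown leave open whether a methyl group, an ethyl group or a longer chain ending in an amine on this nitrogen would hold a number like that of compound 4 or return the read-out to the limit. They also leave open whether hydrogen on this nitrogen would bring a measurable number when the rest of the molecule is that of compound 2 or compound 3.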